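The source may hold more compounds than are shown below. What is called first, only, known or untested is meant among the compounds shown, and "the series" means these compounds.

Working notes on the series.

Two cores are present. Compound 1 `COc1ccc2c(c1)OC(N)=C(C#N)C2c1cccc(Br)c1` and compound 2 `COc1ccc2c(c1)OC(N)=C(C#N)C2c1cccc([N+](=O)[O-])c1` share one core; compound 3 `N#CC1=C(N)Oc2c(ccc(N)c2N)C1c1cccc([N+](=O)[O-])c1` and compound 4 `N#CC1=C(N)Oc2c(ccc(N)c2N)C1c1cccc(Br)c1` share another. How the core of compound 3 differs from the core of compound 2 is not broken down here.

In a functional assay on T47D cells (Homo sapiens) for activation (a lower number here means that less compound is needed, a higher number that more compound is needed for the effect), compound 1 gives 52000000 nM. In this assay compound 2 gives 88900000 nM. In this assay compound 3 gives 390000000 nM; among the three measured compounds it carries the highest number, and its gaps to compound 2 and to compound 1 are both beyond the scatter.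

On the first core the change bromo in place of nitro on an aromatic carbon gave a 1.7-fold lower number from compound 2 to compound 1 (0.23 log units; within the scatter), so the two numbers cannot be told apart. The same change is made on the second core: bromo in place of nitro on an aromatic carbon. The place of the change is the same in both pairs, word for word.

Among the measured compounds shown here, only one earlier step is available as a guide, a 1.7-fold lower number from compound 2 to compound 1 (0.23 log units; within the scatter), and it lies within the scatter. Compound 4 is therefore expected to show a 1.7-fold lower number from compound 3 to compound 4 (0.23 log units; within the scatter), a step of about the same size as that earlier one. Compound 4 is estimated at 230000000 nM, with an expected range from 100000000 nM to 600000000 nM. This rests on a single pair and on one core transfer, and compound 3 stands far from the other two, so the estimate is held loosely.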

Compound 4, half-maximal effective concentration: 150000000 nM
The estimate for compound 4 lay 1.5-fold (0.19 log units) above the measured number; the range from low to high includes it.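

On the second core, in this assay, bromo in place of nitro on an aromatic carbon gave a 2.6-fold lower number from compound 3 to compound 4 (0.41 log units; beyond the scatter). This step lies beyond the scatter while the earlier step on the first core lies within it, yet the two steps themselves cannot be told apart, so the size of the step carried over between these two cores: the same change on two cores in this assay, a 1.7-fold lower number (0.23 log units; within the scatter) from compound 2 to compound 1 and a 2.6-fold lower number (0.41 log units; beyond the scatter) from compound 3 to compound 4, 1.5-fold (0.18 log units) apart, within the scatter of two such steps. Among the compounds shown here, this rests on only two pairs in one assay, so it does not show that the step would hold on any further core, nor does it give a reason for the step, and the first pair alone would not have fixed its direction.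

The compounds shown leave open whether a group other than bromo or nitro at this place, such as an amine or a carboxylic acid, would fit the same picture on both cores. Also open is what the difference between the two cores contributes on its own, since no pair shown isolates any single part of that difference.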